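Swapping the ether aryl group on a piperidinyl pyrimidine core

A few compounds are considered here, and "the series" means these few. Any claim that something is new, unique, unknown or untested is made for them only; others in the source may bear on it.

Measured compounds:
compound 1 `CNC(=O)c1cc(Oc2ccc(Nc3nccc(N4CCCC4)n3)cc2)ccn1`: 59.6%
compound 2 `c1cc(N2CCCCC2)nc(Nc2ccc(Oc3ncnc4sccc34)cc2)n1`: 64.8%

In a functional assay on A549 cells (Homo sapiens) for inhibition, read by MTT assay, with a stated time of 72 h, tested at 20 uM (on this read-out lower numbers stand for less inhibition and higher numbers for more inhibition at the one concentration tested (going by the name of the read-out)), compound 2 gives 64.8%, and compound 1 gives 59.6%; the two values lie within the scatter of each other, so neither can be ranked. Compound 3 `CNC(=O)c1cc(Oc2ccc(Nc3nccc(N4CCCCC4)n3)cc2)ccn1` differs from compound 2 in one place: a group of 10 heavy atoms (7 carbon, 2 nitrogen, 1 oxygen; one six-membered aromatic ring with 1 hetero atom) in place of a group of 9 heavy atoms (6 carbon, 2 nitrogen, 1 sulfur; one five-membered aromatic ring with 1 hetero atom, one six-membered aromatic ring with 2 hetero atoms), on an oxygen on an aromatic ring. Among the compounds with values here, no step between measured compounds is available for this change, and compound 1 already carries the entering group on a related core. Compound 3 is therefore expected to give about 61% (from 46% to 76%) in this assay, a step of a number 3.8 percentage points lower from compound 2 to compound 3 (within the scatter) that is expected to stay within the scatter.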

Compound 3, a percentage reported as inhibition, at one concentration (the size of the read-out at that concentration, not a potency): 63.4%
Compound 3: middle estimate off by 2.4 percentage points, on the low side; the measured number falls inside the stated range.
By their numbers in this assay, from the lowest: compounds 1, 3 and 2 (each within the scatter of the next).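

In this assay, 2-(methylcarbamoyl)pyridin-4-yl on the oxygen, in place of the group with a five-membered and a six-membered aromatic ring, gives a number 1.4 percentage points lower from compound 2 to compound 3 (within the scatter), so these two groups cannot be told apart at this position. Piperidin-1-yl in place of pyrrolidin-1-yl on an aromatic carbon gives a number 3.8 percentage points higher from compound 1 to compound 3 (within the scatter), so these two cannot be told apart there either. Nothing available explains how close these values lie. On these data alone, whether a morpholine at that aromatic carbon, or a carboxylic acid in place of the methylcarbamoyl group, would move the number beyond the scatter remains open.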